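Fluoro in place of hydrogen on the phenyl of compound 1

The source may hold more compounds than are shown below. What is called first, only, known or untested is meant among the compounds shown, and "the series" means these compounds.

Compound 1 `Cc1cccc(NC(=O)CN2CCC(c3ccccc3)CC2)c1` gives 37% in a functional assay on HEK293 cells for agonist activity at D(4) dopamine receptor (Homo sapiens), read by FLIPR (a lower number here means a smaller maximal response, a higher number a larger maximal response), and stands lowest of the two numbers recorded. Among the measured compounds shown here, compound 2 `Cc1cccc(C(=O)NCN2CCC(c3cccc[n+]3[O-])CC2)c1` gives 77% in this assay, a value well beyond the scatter above compound 1, but these two differ in more than one place and no single step connects them. Compound 3 `Cc1cccc(NC(=O)CN2CCC(c3ccccc3F)CC2)c1` differs from compound 1 by fluoro in place of hydrogen on an aromatic carbon. For the measured compounds named here, no measured step of this kind exists, so the expectation rests on compound 1 alone: a small change, not beyond the scatter, in this assay. The expected step is a number 5 percentage points higher from compound 1 to compound 3 (within the scatter). Compound 3 is estimated at 42% in this assay, within 25% to 62%.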

Compound 3, largest response reached (reported as efficacy), in percent of the reference or control that the assay uses: 57%
Beside the measured number, compound 3's estimate is 15 percentage points below it, within the range that was stated.
By their numbers in this assay, from the lowest: compound 1; then compound 3; then compound 2.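

In this assay, among the compounds shown here, the change from phenyl to 2-fluorophenyl gives a number 20 percentage points higher from compound 1 to compound 3 (beyond the scatter) as the first single-place step. This aromatic carbon, ortho to a large group, is therefore a place where one fluoro raises the maximal response beyond the usual scatter. Nothing at hand accounts for the size or direction of this step.

Open, from the compounds shown here alone, is whether chloro, methyl or methoxy at this carbon would move the response the same way. Also open, going by these compounds, is how fluoro would read at the other carbons of the ring.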